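Nitro for methyl on the aryl group of compound 2

The source may hold more compounds than are shown below. What is called first, only, known or untested is meant among the compounds shown, and "the series" means these compounds.

Among the measured compounds shown here, compound 2 `Cc1ccc(-c2nnc(SCCOc3ccc(/C=C4\SC(=O)NC4=O)cc3)[nH]2)cc1` gives 54% in a functional assay on the whole organism (strain Wistar) with Rattus norvegicus as the target, with a stated time of 15 days, at a dose of 100 mg/kg by the oral route (on this read-out lower numbers stand for a weaker effect and higher numbers for a stronger effect at the one dose given), the higher of the two numbers measured so far. For the measured compounds named here, its nearest neighbour, compound 1 `O=C1NC(=O)/C(=C/c2ccc(OCCSc3nnc(Cc4ccccc4)[nH]3)cc2)S1`, gives 41.9% in this assay; the single measured step, a number 12.1 percentage points higher from compound 1 to compound 2 (beyond the scatter), comes from 4-methylphenyl in place of benzyl on an aromatic carbon.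

Compound 3 `O=C1NC(=O)/C(=C/c2ccc(OCCSc3nnc(-c4ccc([N+](=O)[O-])cc4)[nH]3)cc2)S1` is not yet measured in this assay. It differs from compound 2 by nitro in place of methyl on an aromatic carbon, on an aromatic carbon of a six-membered aromatic ring of carbon only, para to a large group; cut one bond further out, the change reads 4-methylphenyl to 4-nitrophenyl.

Going by the values given here, no measured step bears on this change: the step from compound 1 to compound 2 alters how the aryl group joins the shared core, not a substituent on that ring. Nothing in the series speaks for a direction, so a step within the scatter is expected, no change at the digits printed from compound 2 to compound 3 (within the scatter). Compound 3 is therefore estimated at 54% in this assay, within 36% to 70%.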

Compound 3, a percentage reported as activity, at one dose (the size of the read-out at that dose, not a potency): 22.1%
For compound 3 the middle estimate is 31.9 percentage points above the measured one; the whole stated range lies above it.
By their numbers in this assay, from the lowest: compound 3; then compound 1; then compound 2.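

In this assay, among the compounds shown here, the substituent on the six-membered aromatic ring, para to a large group, proves to matter: nitro in place of methyl gives a number 31.9 percentage points lower from compound 2 to compound 3 (beyond the scatter), the largest step so far, whereas the earlier step changed only how the aryl group joins the shared core. The comparison with the benzyl compound also changes when the group on the ring changes: 4-methylphenyl in place of benzyl gave a number 12.1 percentage points higher from compound 1 to compound 2 (beyond the scatter), but 4-nitrophenyl in place of benzyl gives a number 19.8 percentage points lower from compound 1 to compound 3 (beyond the scatter), so direct attachment of an aryl group does not by itself raise the number in this assay. Nothing available on these compounds accounts for the drop with nitro.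

Going by these compounds, with only methyl and nitro at this place, it remains open where an unsubstituted phenyl, a chlorine, a methoxy group or an amine would fall relative to compound 2 and compound 3. On these data alone, each compound is also read at a single dose, so whether this order holds at other doses remains open.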